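A few compounds are considered here, and "the series" means these few. Any claim that something is new, unique, unknown or untested is made for them only; others in the source may bear on it.

Three amides on a shared core have been read so far in a functional assay on HL-60 cells (Homo sapiens) for inhibition, read by MTT assay, with a stated time of 72 h (on this read-out higher numbers stand for weaker inhibition and lower numbers for stronger inhibition), and only one of them gives a number. In this assay compound 1 (`COc1ccc(-c2nc(C)oc2C(=O)N2CCN(c3cccc(Cl)c3)CC2)cc1OC`) is recorded as "not active" (no number reported) and compound 3 (`COc1ccc(-c2nc(C)oc2C(=O)N2CCN(c3cccc(Cl)c3)CC2)cc1O`) as "not active" (no number reported) with no figure attached. Compound 2 (`Cc1nc(-c2ccc(F)cc2)c(C(=O)N2CCN(c3cccc(Cl)c3)CC2)o1`) reaches 40.1 nM in the same read-out. Compound 3 therefore has no single value and stands with compound 1 as the one further entry of its kind, and no measured step links any of these compounds.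

Compound 4 (`Cc1nc(-c2cccc(O)c2)c(C(=O)N2CCN(c3cccc(Cl)c3)CC2)o1`) differs from compound 3 in one place: hydrogen in place of methoxy on an aromatic carbon is the change, hydrogen in place of methoxy on an aromatic carbon, turning 3-hydroxy-4-methoxyphenyl into 3-hydroxyphenyl. Compound 1 and compound 3 both carry a methoxy group para to a large group, while compound 2 has none there. On this thin basis, a step towards stronger inhibition is expected in this assay but its size cannot be fixed, as compound 3 offers no number to start from. Compound 2 at 40.1 nM serves as the nearest guide, and a result without a number remains possible. Compound 4 is expected at about 200 nM with an estimated range from 30 nM to 2000 nM as its bounds.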

Compound 4, half-maximal inhibitory concentration: 105 nM
Compound 4: middle estimate off by 1.9-fold (0.28 log units), on the high side, within the range that was stated.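

In this assay compound 3 is recorded as "not active" (no number reported), while compound 4, with hydrogen in place of methoxy para to a large group, gives 105 nM. The change from compound 3 to compound 4 therefore separates an entry without a number from one with a number, though its size cannot be read. Both compounds keep the hydroxy group, so this pair shows that the hydroxy group does not by itself go with a result lacking a number, and 3-hydroxyphenyl in place of 4-fluorophenyl gives a 2.6-fold higher number from compound 2 to compound 4 (0.42 log units; beyond the scatter), a modest step beyond the scatter.

No measurement shown here accounts for either of these differences. On these data alone, it remains open whether only methoxy gives this outcome at the place para to a large group, or whether an ethoxy group, an amine or a carboxylic acid there, with the hydroxy group kept, would also leave the compound without a number in this assay.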